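Working notes: hydroxy to hydrogen, compound 1 to compound 4

This account rests on a few compounds, and the source may have more. Where it says the series, first, only, none or still open, it means among the compounds named here.

Compound 1 `O=C(Nc1ccccc1)c1cc(Br)ccc1O` is the reference point of this small set. For the measured compounds named here, in an ADME assay on HEK293 cells (Homo sapiens) for cytotoxicity, read by reporter gene assay and resazurin assay, with a stated time of 48 h (a lower number here means that less compound is tolerated, a higher number that more compound is tolerated), compound 1 gives 35000 nM, the highest of the three numbers measured so far. Compound 2 `O=C(Nc1ccccc1)c1cc(Br)cc(Br)c1O` gives 34000 nM in this assay; the change from compound 1 to compound 2, bromo in place of hydrogen on an aromatic carbon, amounts to a 1.0-fold lower number from compound 1 to compound 2 (0.01 log units; within the scatter). Compound 3 `O=C(Nc1cccc(Cl)c1)c1cc(Br)ccc1O` gives 15000 nM in this assay; here chloro in place of hydrogen on an aromatic carbon amounts to a 2.3-fold lower number from compound 1 to compound 3 (0.37 log units; beyond the scatter), a modest move to a lower number.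

Compound 4 `O=C(Nc1ccccc1)c1cccc(Br)c1` differs from compound 1 in one place: hydrogen in place of hydroxy on an aromatic carbon. Neither measured step touches the hydroxy; both add a halogen on an aromatic carbon elsewhere on the shared core, so neither bears directly on this change. The two steps together span from within the scatter to a modest lower number, and that is the only scale available. For compound 4 in this assay no step beyond the scatter is expected in either direction, with a wide range to reflect the absence of a directly comparable step. Compound 4 is estimated at 35000 nM in this assay, with a range from 15000 nM to 80000 nM. The expected step is no change at the digits printed from compound 1 to compound 4 (within the scatter).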

Compound 4, half-maximal cytotoxic concentration: > 100000 nM
Compound 4: a limit, no number; the forecaster's own chance of this, stated with the estimate: 15%; at least 2.8-fold (0.45 log units) between middle value and limit.
By their numbers in this assay, from the lowest: compound 3; then compounds 2 and 1 (each within the scatter of the next). At a limit, above all of these: compound 4.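

For compound 4 the reading in this assay is a limit of the assay and not a number: the limit of > 100000 nM in this assay, at which 1 of the 4 values shown sits. Hydrogen in place of hydroxy, on the aromatic carbon ortho to a group of 9 heavy atoms and para to a bromo group, gives an at least 2.8-fold higher number from compound 1 to compound 4 (0.45 log units; beyond the scatter), and this is the only step shown that moves to a higher number. For the compounds shown here, the two halogen steps elsewhere on the shared core gave a 1.0-fold lower number from compound 1 to compound 2 (0.01 log units; within the scatter) and a 2.3-fold lower number from compound 1 to compound 3 (0.37 log units; beyond the scatter), so in this small set the hydroxy position is the one place where a change allows more compound to be tolerated, and the true size of that step remains unknown beyond the printed bound.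

From the compounds shown here alone, whether this rise depends on losing the hydroxy specifically or would also follow from another group at this position stays open, and a methoxy group, an amine or a fluoro group there would separate those readings. Also open, going by these compounds, is whether the same change, made on compound 2 or compound 3, gives a step in the same direction when the added halogen is present.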